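Removing the Fluoro from Compound 2

This account rests on a few compounds, and the source may have more. Where it says the series, first, only, none or still open, it means among the compounds named here.

Compound 2 `O=[N+]([O-])c1cc2c(OCCC3CCCCN3)c(-c3cccc(F)c3)c(O)nc2cc1Cl` gives 53 nM in a functional assay on cells (Pituitary gland cell) for antagonist activity at Gonadotropin-releasing hormone receptor (Rattus norvegicus) (a lower number here means a stronger inhibitor, a higher number a weaker inhibitor), and stands as the higher of the two numbers shown, a gap within the scatter to compound 1 `CC(=O)OCc1cc(C)cc(-c2c(O)nc3cc(Cl)c([N+](=O)[O-])cc3c2OCCC2CCCCN2)c1`, which gives 45 nM. The step of a 1.2-fold higher number from compound 1 to compound 2 (0.07 log units; within the scatter) stayed within the scatter. Compound 3 `O=[N+]([O-])c1cc2c(OCCC3CCCCN3)c(-c3ccccc3)c(O)nc2cc1Cl` differs from compound 2 by hydrogen in place of fluoro on an aromatic carbon; cut one bond further out, this reads 3-fluorophenyl to phenyl. For the measured compounds named here, no measured step touches this exact change. Going by the values given here, the only step seen, a far larger exchange on the same ring, lay within the scatter. For compound 3 the expected step is therefore a 1.1-fold higher number from compound 2 to compound 3 (0.05 log units; within the scatter). Compound 3 is therefore estimated at 60 nM, between 25 nM and 150 nM.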

Compound 3, half-maximal inhibitory concentration: 410 nM
Beside the measured number, compound 3's estimate is 6.8-fold (0.83 log units) below it; measured number outside the range, above it.
By their numbers in this assay, from the lowest: compounds 1 and 2 (each within the scatter of the next); then compound 3.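

In this assay, this single aromatic carbon proves far more sensitive than the earlier pair suggested: hydrogen in place of fluoro gives a 7.7-fold higher number from compound 2 to compound 3 (0.89 log units; beyond the scatter). The bare phenyl also trails the 3-(acetoxymethyl)-5-methylphenyl, with a 9.1-fold higher number from compound 1 to compound 3 (0.96 log units; beyond the scatter), so two very different substituted rings lie within the scatter of each other while the unsubstituted ring stands apart. Nothing available explains this loss. The compounds shown leave open whether fluoro itself matters or whether another group on this carbon, such as methoxy or nitrile, would serve equally well.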